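From acetyl to a silicon-bearing group on compound 1

This account rests on a few compounds, and the source may have more. Where it says the series, first, only, none or still open, it means among the compounds named here.

Compound 1 (`COc1ccc(C2=C(c3cc(OC)c(OC)c(OC)c3)C(=O)C(OC(C)=O)C2)cc1OC(C)C`) sits at the weak end of an ADME assay on HEp-2 cells (Homo sapiens) for cytotoxicity, read by MTT assay, with a stated time of 72 h (on this read-out lower numbers stand for stronger inhibition and higher numbers for weaker inhibition), where compound 1 gives > 100 ug/mL, a limit and not a number. Compound 2 (`COc1ccc(C2=C(c3cc(OC)c(OC)c(OC)c3)C(=O)C(OC(C)=O)C2)cc1F`) gives < 1 ug/mL, also a limit. Compound 3 (`COc1ccc(C2=C(c3cc(OC)c(OC)c(OC)c3)C(=O)C(O[SiH2]C(C)(C)C)C2)cc1OC(C)C`) keeps the isopropoxy group of compound 1 and differs elsewhere: a group of 5 heavy atoms (4 carbon, 1 silicon; no ring) in place of a group of 3 heavy atoms (2 carbon, 1 oxygen; no ring), on an oxygen on a saturated carbon. For the measured compounds named here, the only measured step, an at least 100-fold lower number from compound 1 to compound 2 (2.00 log units; beyond the scatter), is large, but it lies on an aromatic carbon and gives no size for a change on this oxygen. No change beyond the scatter is expected, the estimated step being an at least 1.2-fold lower number from compound 1 to compound 3 (0.09 log units; that floor lies within the scatter). For compound 3 the expected value is 80 ug/mL, within an estimated range of 15 ug/mL to 150 ug/mL.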

Compound 3, half-maximal inhibitory concentration: 7.1 ug/mL
Compound 3: the middle estimate sits 11-fold (1.05 log units) above what was measured, outside the stated range (below it).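

The oxygen on a saturated carbon turns out to be a position that responds: with the isopropoxy group kept, the group of 5 heavy atoms (4 carbon, 1 silicon) in place of acetyl gives an at least 14-fold lower number from compound 1 to compound 3 (1.14 log units; beyond the scatter). For the compounds shown here, the aromatic carbon carrying fluoro in compound 2 is therefore not the only place where a change moves the result in this assay. The size of this step is only a floor, because compound 1 stands at a limit: the limit of > 100 ug/mL in this assay, at which 1 of the 3 values shown sits.

From the compounds shown here alone, what a free hydroxyl or a plain tert-butyl ether on this oxygen would give stays open. So does whether the silicon atom itself matters, and how this group would behave alongside fluoro.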